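The compounds below may be only part of what the source reports. "The series", "measured", "known", "first", "only" and "open" are said of these compounds alone.

Measured so far in a functional assay on B16-F10 cells (Mus musculus) for inhibition, read by MTT assay, with a stated time of 48 h; on this read-out lower numbers stand for stronger inhibition and higher numbers for weaker inhibition:
Compound 1 `O=C(/C=C/c1ccccc1Cl)Nc1ccc2ncnc(Nc3cccc(Br)c3)c2c1` gives 2 ug/mL.
Compound 2 `O=C(/C=C/c1ccc(Br)cc1)Nc1ccc2ncnc(Nc3cccc(Br)c3)c2c1` gives 10.7 ug/mL.
Compound 3 `O=C(/C=C/c1ccccc1Cl)Nc1ccc2ncnc(Nc3cccc(Cl)c3)c2c1` gives 1.74 ug/mL.

Compound 4 `O=C(/C=C/c1ccc(Br)cc1)Nc1ccc2ncnc(Nc3cccc(Cl)c3)c2c1` is not yet measured. It differs from compound 3 by 4-bromophenyl in place of 2-chlorophenyl on a double-bonded chain carbon bound to a double-bonded chain carbon. The same change has been made once already, and that move gave a 5.4-fold higher number from compound 1 to compound 2 (0.73 log units; beyond the scatter). The cores of the two pairs differ by chloro in place of bromo on an aromatic carbon, a change that gave a 1.1-fold lower number from compound 1 to compound 3 (0.06 log units; within the scatter), so the two starting points stand close together. The place of the change is the same in both pairs, so the change counts as the same change. The step expected from compound 3 to compound 4 is a 5.4-fold higher number from compound 3 to compound 4 (0.73 log units; beyond the scatter), resting on the earlier step of a 5.4-fold higher number from compound 1 to compound 2 (0.73 log units; beyond the scatter). Compound 4 is therefore estimated at 9.4 ug/mL, with a likely range from 4.5 ug/mL to 20 ug/mL.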

Compound 4, half-maximal inhibitory concentration: 0.75 ug/mL
Estimate against measurement, compound 4: 13-fold (1.10 log units) above, and the stated range ends above it.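

In this assay the swap to 4-bromophenyl in place of 2-chlorophenyl does not carry from one core to the other, giving a 2.3-fold lower number from compound 3 to compound 4 (0.37 log units; beyond the scatter) and reversing the direction of the earlier step: the same change on two cores in this assay, a 5.4-fold higher number (0.73 log units; beyond the scatter) from compound 1 to compound 2 and a 2.3-fold lower number (0.37 log units; beyond the scatter) from compound 3 to compound 4, 12-fold (1.09 log units) apart, beyond the scatter of two such steps. The change of chloro in place of bromo on an aromatic carbon also depends on its context, giving a 14-fold lower number from compound 2 to compound 4 (1.15 log units; beyond the scatter) on this core: the same change on two cores in this assay, a 1.1-fold lower number (0.06 log units; within the scatter) from compound 1 to compound 3 and a 14-fold lower number (1.15 log units; beyond the scatter) from compound 2 to compound 4, 12-fold (1.09 log units) apart, beyond the scatter of two such steps. The two changes do not add independently across these four compounds, but this single set shows neither why that is so nor whether it holds for other groups.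

As far as these compounds go, it remains open how a methoxy group or a fluoro group in place of chloro on an aromatic carbon would behave. From the compounds shown here alone, whether an amine in place of 4-bromophenyl would follow either step also remains open.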